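The source may hold more compounds than are shown below. What is called first, only, known or untested is meant among the compounds shown, and "the series" means these compounds.

Measured so far:
Compound 1 `O=C(O)CCc1ccc(OCc2coc(-c3cccc(F)c3)n2)cc1` — 560 nM
Compound 2 `O=C(O)CCc1ccc(OCc2nc(-c3ccccc3)no2)cc1` — 1130 nM
Compound 3 `CCc1ccc(-c2noc(COc3ccc(CCC(=O)O)cc3)n2)cc1` — 210 nM

In a functional assay on CHO cells for agonist activity at Free fatty acid receptor 1 (Homo sapiens), read by FLIPR and calcium flux, in the presence of a further agent that is not named here (on this read-out lower numbers stand for an effect already at smaller amounts and higher numbers for an effect only at larger amounts of compound), compound 3 gives the lowest of the three numbers. Its nearest neighbour is compound 1, whose value in this assay is 560 nM, and the gap to it lies beyond the scatter. Compound 2, with 1130 nM in this assay, is the furthest away.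

Compound 4 `Cc1ccc(-c2noc(COc3ccc(CCC(=O)O)cc3)n2)cc1` is not yet measured. It differs from compound 3 in one place: hydrogen in place of methyl on a saturated chain carbon bound to an aromatic carbon, read one bond further out as 4-ethylphenyl to 4-methylphenyl.

Going by the values given here, only one measured step bears on this change. It is a 5.4-fold lower number from compound 2 to compound 3 (0.73 log units; beyond the scatter). Compound 4 sits between those two endpoints, carrying methyl where compound 2 carries hydrogen and compound 3 carries ethyl. It is therefore expected to give a higher number than compound 3 in this assay, but not as high as compound 2, so that the step of a 2.0-fold higher number from compound 3 to compound 4 (0.30 log units; within the scatter) is estimated as a partial reversal of the measured one.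

Accordingly, compound 4 is expected to give 420 nM in this assay, with a range from 200 nM to 900 nM.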

Compound 4, half-maximal effective concentration: 300 nM
The estimate for compound 4 lay 1.4-fold (0.15 log units) above the measured number; the measured number falls inside the stated range.
By their numbers in this assay, from the lowest: compounds 3, 4, 1 and 2 (each within the scatter of the next, the first and the last beyond it).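

In this assay the step of a 1.4-fold higher number from compound 3 to compound 4 (0.15 log units; within the scatter) shows that ethyl and methyl on this aromatic carbon cannot be told apart, so the extra carbon of the 4-ethylphenyl group has no effect that can be read here. Going by these compounds alone, the step of a 3.8-fold lower number from compound 2 to compound 4 (0.58 log units; beyond the scatter) shows that a single methyl in place of hydrogen on an aromatic carbon is already enough to move the number beyond the scatter, whereas the earlier compounds showed such a move only for ethyl. No measurement bears on why either step has this size.

The compounds shown leave open whether a longer chain such as propyl or butyl would keep the number in the range of compound 3 and compound 4 or move it away from them, and whether a methoxy group, a chlorine atom or a trifluoromethyl group at this place would give a similar step. They also leave open whether methyl or ethyl on the phenyl ring of compound 2 would give a step of similar size on another core.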